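This account rests on a few compounds, and the source may have more. Where it says the series, first, only, none or still open, it means among the compounds named here.

Working notes on the series. Compound 1 `CC(C)(CCN(C[C@H]1Cc2ccccc2CN1)[C@H]1CCCc2cccnc21)CNCC1CCOCC1` and compound 2 `CC(C)(CCN(C[C@H]1Cc2ccccc2CN1)[C@H]1CCCc2cccnc21)CNC1CCC(F)(F)CC1` share one core and differ only at the amine nitrogen of the side chain. In a functional assay on cells for agonist activity at C-X-C chemokine receptor type 4 (Homo sapiens), read by fluorescence and calcium flux, with a stated time of 90 s (on this read-out higher numbers stand for an effect only at larger amounts of compound and lower numbers for an effect already at smaller amounts), compound 1 gives only a limit, > 30000 nM. In this assay compound 2 likewise gives only a limit, > 30000 nM. Among the compounds with values here, the single measured step, a step that the two limits leave unreadable from compound 1 to compound 2, therefore has no readable size; both of its values sit at the limit of > 30000 nM in this assay, at which 2 of the 2 values shown sit. Compound 3 `CC1(C)CCC(NCC(C)(C)CCN(C[C@H]2Cc3ccccc3CN2)[C@H]2CCCc3cccnc32)CC1` differs from compound 2 by 4,4-dimethylcyclohexyl in place of 4,4-difluorocyclohexyl on an amine nitrogen. Within the data shown here, no measured step bears on this exchange directly, and the one step known gives no size to lean on, so no direction beyond the scatter can be claimed. In this assay the step is expected to be a number no higher from compound 2 to compound 3 (the limit leaves the size open). Compound 3 is expected to give roughly 30000 nM in this assay, within a range of 10000 nM to 100000 nM, most likely again returned only as a limit.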

Compound 3, half-maximal effective concentration: > 30000 nM
Compound 3: only a limit was reported (the forecaster's own chance of this, stated with the estimate: 80%); the middle value sits exactly at the limit.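

Within the data shown here, compound 3 in this assay gives only a limit, as do compound 1 and compound 2, so no step among the three can be read: the limit of > 30000 nM in this assay, at which 3 of the 3 values shown sit. The compounds shown leave open whether any group on this amine nitrogen gives a measurable value in this assay and how the three groups compare.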